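Swapping diethylamino for benzyl(methyl)amino on the shared core

A few compounds are considered here, and "the series" means these few. Any claim that something is new, unique, unknown or untested is made for them only; others in the source may bear on it.

Of the compounds shown here, three built on a shared core have been tested in a functional assay on the whole organism for positive allosteric modulation, with Mus musculus as the target; on this read-out lower numbers stand for an effect already at smaller amounts and higher numbers for an effect only at larger amounts of compound. Compound 1 `CCC(=O)N(c1ccc(C)c(Cl)c1)C1CCCC1N(C)C` gives 2 mg/kg. Compound 2 `CCC(=O)N(c1ccc(C#N)cc1)C1CCCC1N(C)C` is recorded at > 50 mg/kg, which is a limit of the assay and not a number. Compound 3 `CCC(=O)N(c1ccc(Cl)c(Cl)c1)C1CCCC1N(CC)CC` gives 0.3 mg/kg, the lower of the two actual numbers, and its distance from compound 1 lies beyond the usual scatter.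

Compound 4 `CCC(=O)N(c1ccc(Cl)c(Cl)c1)C1CCCC1N(C)Cc1ccccc1` departs from compound 3 at a single place, with benzyl(methyl)amino in place of diethylamino on a saturated ring carbon. The incoming group brings one six-membered aromatic ring of carbon only. Among the measured compounds shown here, no two measured compounds differ in one place alone, so the data offer no direct precedent for this step. Compound 3 already sits at the low end with 0.3 mg/kg, so a rise beyond the scatter in this assay is expected, though with wide uncertainty. The expected move is an 8.3-fold higher number from compound 3 to compound 4 (0.92 log units; beyond the scatter). For compound 4 the estimated value is 2.5 mg/kg, within an expected range from 0.4 mg/kg to 15 mg/kg.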

Compound 4, dose for half-maximal effect: > 50 mg/kg
Compound 4: only a limit was reported; the forecaster's own chance of this, stated with the estimate: 10%; at least 20-fold (1.30 log units) between middle value and limit.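

Among the compounds shown here, this is the first change that can be read at this position alone, with the rest of compound 3 held fixed. In this assay, benzyl(methyl)amino in place of diethylamino on a saturated ring carbon goes with an at least 160-fold higher number from compound 3 to compound 4 (2.22 log units; beyond the scatter), so the amine on this carbon strongly shapes the read-out and this change is far from neutral. Compound 4 is recorded at > 50 mg/kg, which is a limit of the assay and not a number, so the step has only a lower bound and its true size is unknown, with a second compound also sitting at that limit: the limit of > 50 mg/kg in this assay, at which 2 of the 4 values shown sit.

From the compounds shown here alone, it remains open whether the six-membered aromatic ring or the larger size of the incoming group goes with this rise. A piperidine or a cyclohexyl(methyl)amino group on the same carbon, with the rest of compound 3 unchanged, would separate the two.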